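The compounds below may be only part of what the source reports. "The series", "measured", "known", "first", "only" and "open" are said of these compounds alone.

Compound 1 `C#CCOc1cccc(/C=C/C(=O)Nc2cc(C(=O)c3cc(OC)c(OC)c(OC)c3)ccc2OC)c1` is the reference of this small set. In a functional assay on ME-180 cells (Homo sapiens) for cytotoxicity, read by MTT assay, with a stated time of 72 h (a lower number here means a stronger inhibitor, a higher number a weaker inhibitor), compound 1 gives 15300 nM. Compound 2 `COc1ccc(C(=O)c2cc(OC)c(OC)c(OC)c2)cc1NC(=O)/C=C/c1ccc(F)cc1` gives 300 nM in this assay, and compound 3 `C#CCOc1cccc(/C=C/C(=O)Nc2cc(C(=O)c3cc(OC)c(OC)c(OC)c3)cc(OC)c2OC)c1` gives 8400 nM in this assay.

Two single changes connect the measured compounds. The first, (4-fluorophenyl in place of 3-(propargyloxy)phenyl on a double-bonded chain carbon bound to a double-bonded chain carbon), produced a 51-fold lower number from compound 1 to compound 2 (1.71 log units; beyond the scatter). The second, (methoxy in place of hydrogen on an aromatic carbon), produced a 1.8-fold lower number from compound 1 to compound 3 (0.26 log units; within the scatter), so the two cores behave alike within the scatter.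

Compound 4 `COc1cc(C(=O)c2cc(OC)c(OC)c(OC)c2)cc(NC(=O)/C=C/c2ccc(F)cc2)c1OC` carries the change 4-fluorophenyl in place of 3-(propargyloxy)phenyl on a double-bonded chain carbon bound to a double-bonded chain carbon on the core of compound 3. The place of the change is the same as for the change from compound 1 to compound 2, so this is the same change made on a core that differs only by methoxy in place of hydrogen on an aromatic carbon.

The step expected from compound 3 to compound 4 in this assay is a 42-fold lower number from compound 3 to compound 4 (1.62 log units; beyond the scatter); this rests on a 51-fold lower number from compound 1 to compound 2 (1.71 log units; beyond the scatter) and on the core step a 1.8-fold lower number from compound 1 to compound 3 (0.26 log units; within the scatter) being within the scatter. Compound 4 is therefore estimated at 200 nM, with a likely range from 70 nM to 600 nM.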

Compound 4, half-maximal inhibitory concentration: 1000 nM
Beside the measured number, compound 4's estimate is 5.0-fold (0.70 log units) below it; the measured number lies above the stated range.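

In this assay, the change to 4-fluorophenyl on the core of compound 3 gives an 8.4-fold lower number from compound 3 to compound 4 (0.92 log units; beyond the scatter), so the direction of the step carries from one core to the other, but its size does not: the same change on two cores in this assay, a 51-fold lower number (1.71 log units; beyond the scatter) from compound 1 to compound 2 and an 8.4-fold lower number (0.92 log units; beyond the scatter) from compound 3 to compound 4, 6.1-fold (0.78 log units) apart, beyond the scatter of two such steps

The same four compounds read through the added methoxy give a 3.3-fold higher number from compound 2 to compound 4 (0.52 log units; beyond the scatter), whereas the step between the two compounds with 3-(propargyloxy)phenyl stays within the scatter: the same change on two cores in this assay, a 1.8-fold lower number (0.26 log units; within the scatter) from compound 1 to compound 3 and a 3.3-fold higher number (0.52 log units; beyond the scatter) from compound 2 to compound 4, 6.1-fold (0.78 log units) apart, beyond the scatter of two such steps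

Both comparisons rest on one set of four compounds and describe a single departure from additivity; they show that the two changes are not independent here, but not why, and they give no rule for other groups.

Still open, going by these compounds, is whether the dependence on the core appears with other groups at this place, such as a phenyl ring carrying an amine or a carboxylic acid, or a longer chain in place of propargyloxy. Also open, on these data alone, is whether a second methoxy-bearing pair would repeat the higher number seen with compound 4.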